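Extending the urea side chain of compound 3

The compounds below may be only part of what the source reports. "The series", "measured", "known", "first", "only" and "open" are said of these compounds alone.

Measured compounds:
Compound 1 `CCN(CC)CCNC(=O)Nc1nc2ccc(-c3cnc(OC)c(NS(=O)(=O)c4ccc(F)cc4)c3)cc2s1`: in a functional assay on A549 cells (Homo sapiens) for antiproliferative activity, read by MTT assay, with a stated time of 72 h (a higher number here means a weaker inhibitor, a lower number a stronger inhibitor), compound 1 gives 450 nM.
Compound 2 `COc1ncc(-c2ccc3nc(NC4CC4)sc3c2)cc1NS(=O)(=O)c1ccc(F)cc1`: in this assay compound 2 gives 1330 nM.
Compound 3 `CNC(=O)Nc1nc2ccc(-c3cnc(OC)c(NS(=O)(=O)c4ccc(F)cc4)c3)cc2s1`: in this assay compound 3 gives 1560 nM.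

Among these three, compound 3 has the highest number; its gap to compound 2 is within the scatter, while compound 1 sits clearly lower, as the step of a 3.5-fold higher number from compound 1 to compound 3 (0.54 log units; beyond the scatter) shows. Compound 4 `COc1ncc(-c2ccc3nc(NC(=O)NCCN4CCN(C)CC4)sc3c2)cc1NS(=O)(=O)c1ccc(F)cc1` differs from compound 3 by (4-methylpiperazin-1-yl)methyl in place of hydrogen on a saturated chain carbon bound to an amide-type nitrogen. Going by the values given here, the step bearing on this is the one from compound 1 to compound 3, where removing a similar side chain raised the number a 3.5-fold higher number from compound 1 to compound 3 (0.54 log units; beyond the scatter). Adding a chain back is therefore expected to lower the number by a modest amount, a 2.8-fold lower number from compound 3 to compound 4 (0.45 log units; beyond the scatter). For compound 4 the estimate is 550 nM, with a range from 220 nM to 1400 nM.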

Compound 4, half-maximal inhibitory concentration: 550 nM
Compound 4: middle estimate and measured number agree at the digits printed; the range from low to high includes it.
By their numbers in this assay, from the lowest: compounds 1 and 4 (each within the scatter of the next); then compounds 2 and 3 (each within the scatter of the next).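

The step of a 2.8-fold lower number from compound 3 to compound 4 (0.45 log units; beyond the scatter) shows that the gain seen with the diethylamino chain of compound 1 in this assay is not tied to that one group, and the step of a 2.4-fold lower number from compound 2 to compound 4 (0.38 log units; beyond the scatter) sets the new chain apart from cyclopropyl as well. With 4-methylpiperazin-1-yl in place of diethylamino, the step of a 1.2-fold higher number from compound 1 to compound 4 (0.09 log units; within the scatter) leaves the two chains indistinguishable. Nothing available explains these steps. Still open, from the compounds shown here alone, is whether the amine matters at all, which a 2-methoxyethyl chain would test, and whether a longer chain such as 3-(4-methylpiperazin-1-yl)propyl would lower the number further.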